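Adding a Third Methoxy Group: From Compound 3 to Compound 4

A few compounds are considered here, and "the series" means these few. Any claim that something is new, unique, unknown or untested is made for them only; others in the source may bear on it.

Compound 3 `COc1ccc(CNc2nc3cc(N)cc(N)c3nc2-c2ccccc2)cc1OC` stands second highest of the three numbers in a functional assay on NCI-H460 cells (Homo sapiens) for inhibition, read by sulforhodamine B assay, with a stated time of 48 h (a higher number here means a weaker inhibitor of growth, a lower number a stronger inhibitor of growth), giving 24000 nM. Compound 2 `Nc1cc(N)c2nc(-c3ccccc3)c(NCc3ccc(Cl)c(Cl)c3)nc2c1` gives 20900 nM and compound 1 `CCOC(=O)[C@H](CCC(=O)O)NC(=O)c1ccc(CNc2nc3cc(N)cc(N)c3nc2-c2ccccc2)cc1` gives 31600 nM; all three lie within the scatter of one another. Compound 4 `COc1cc(CNc2nc3cc(N)cc(N)c3nc2-c2ccccc2)cc(OC)c1OC` differs from compound 3 by methoxy in place of hydrogen on an aromatic carbon. For the measured compounds named here, the one measured step that touches this part of the molecule, a 1.1-fold higher number from compound 2 to compound 3 (0.06 log units; within the scatter), exchanged the whole 3,4-dichlorophenyl for 3,4-dimethoxyphenyl and stayed within the scatter. A single added methoxy on the same ring is therefore expected to move the number no further than the scatter allows. The estimate for compound 4 in this assay is 25000 nM, with a range from 10000 nM to 60000 nM. This amounts to an expected step of a 1.0-fold higher number from compound 3 to compound 4 (0.02 log units; within the scatter).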

Compound 4, concentration for 50% growth inhibition: 1510 nM
For compound 4 the middle estimate is 17-fold (1.22 log units) above the measured one; the whole stated range lies above it.
By their numbers in this assay, from the lowest: compound 4; then compounds 2, 3 and 1 (each within the scatter of the next).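

In this assay, methoxy in place of hydrogen at this position gives a 16-fold lower number from compound 3 to compound 4 (1.20 log units; beyond the scatter), whereas the exchange of both ring substituents in a 1.1-fold higher number from compound 2 to compound 3 (0.06 log units; within the scatter) changed little. Methoxy groups as such therefore do not account for the gain: compound 3 carries two and stays within the scatter of compound 2, which has none. Nothing available explains why the third methoxy has this effect.

From the compounds shown here alone, whether a hydroxyl, an amine or an ethoxy group at this position would do the same remains open. So does whether the gain depends on the two neighbouring methoxy groups.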